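Compound 2 to compound 4: a methoxymethyl step

The source may hold more compounds than are shown below. What is called first, only, known or untested is meant among the compounds shown, and "the series" means these compounds.

In a functional assay on MDA-MB-231 cells (Homo sapiens) for antiproliferative activity, read by MTT assay (on this read-out higher numbers stand for weaker inhibition and lower numbers for stronger inhibition), compound 2 (`CCCCC/C=C\C/C=C\CCCCCCCc1cc(=O)c2c(O)cc(O)c(C)c2o1`) gives 6790 nM. Compound 1 (`CC/C=C\C/C=C\C/C=C\CCCCCCCc1cc(=O)c2c(O)cc(OCOC)c(C)c2o1`) gives 6790 nM, and compound 3 (`CC/C=C\C/C=C\C/C=C\CCCCCCCc1cc(=O)c2c(O)cc(O)c(C)c2o1`) gives 6790 nM. Compound 2 therefore stands level with compound 1 and compound 3, and no order can be drawn among them.

Compound 4 (`CCCCC/C=C\C/C=C\CCCCCCCc1cc(=O)c2c(O)cc(OCOC)c(C)c2o1`) is still unmeasured. It keeps the chain of compound 2, and the change is methoxymethyl in place of hydrogen on an oxygen on an aromatic ring. Read one bond further out, this is hydroxy to methoxymethoxy.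

For the measured compounds named here, two measured steps bear on this. The closer one is the same group change in the reverse sense, on the other chain: no change at the digits printed from compound 1 to compound 3 (within the scatter). The second is the chain change itself: no change at the digits printed from compound 2 to compound 3 (within the scatter). Neither step leaves the scatter, so the series offers no case in which either change moves the value. Going by the values given here, this rests on only three compounds, all at one value, and the group change has not been measured on the chain of compound 2.

No step beyond the scatter is therefore expected in this assay. The estimated no change at the digits printed from compound 2 to compound 4 (within the scatter) carries no favoured direction. For compound 4 the expected value is 6790 nM, with an estimated range of 3500 nM to 13000 nM.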

Compound 4, half-maximal inhibitory concentration: 16100 nM
Beside the measured number, compound 4's estimate is 2.4-fold (0.37 log units) below it; the whole stated range lies below it.
By their numbers in this assay, from the lowest: compounds 1, 2 and 3 (each within the scatter of the next); then compound 4.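

In this assay, for the compounds shown here, the two changes that looked silent among the earlier compounds now register once they meet in compound 4: methoxymethyl in place of hydrogen on an oxygen on an aromatic ring gives a 2.4-fold higher number from compound 2 to compound 4 (0.37 log units; beyond the scatter), and butyl in place of but-1-en-1-yl, with methoxymethyl kept on that oxygen, gives a 2.4-fold higher number from compound 1 to compound 4 (0.37 log units; beyond the scatter), both modest. Even so, the group change cannot yet be said to depend on the chain, since its two readings do not separate: the same change on two cores in this assay, no change at the digits printed (within the scatter) from compound 1 to compound 3 and a 2.4-fold lower number (0.37 log units; beyond the scatter) from compound 4 to compound 2, 2.4-fold (0.37 log units) apart, within the scatter of two such steps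

Nor can the chain change be said to depend on what sits on the oxygen, since its two readings do not separate either: the same change on two cores in this assay, no change at the digits printed (within the scatter) from compound 2 to compound 3 and a 2.4-fold lower number (0.37 log units; beyond the scatter) from compound 4 to compound 1, 2.4-fold (0.37 log units) apart, within the scatter of two such steps

The compounds shown leave open whether methyl or benzyl on the same oxygen would follow compound 4 or stay level with compound 2. They also leave open whether a longer chain, or a chain carrying an amine or a carboxylic acid, would move the value in this series, with or without methoxymethyl on that oxygen.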